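The source may report more compounds than this note shows. Statements on the series, on what has been measured and on what is new or still open speak of the compounds shown alone.

Measured so far:
compound 1 `CCOc1ccc(NC(=O)Nc2cc(C(C)(C)C)nn2-c2ccccc2)cc1`, 1.1 degrees C
compound 2 `CC(C)(C)c1cc(NC(=O)Nc2ccc(F)c(F)c2)n(-c2ccccc2)n1`, 5.5 degrees C

Going by the values given here, in an assay on isolated protein for inhibition of STE20-like serine/threonine-protein kinase (Homo sapiens), read by thermal shift assay, tested at 10 uM (on this read-out lower numbers stand for weaker stabilisation of the target and higher numbers for stronger stabilisation of the target against heat), compound 1 gives 1.1 degrees C and compound 2 gives 5.5 degrees C. The single step between them, a number 4.4 degrees C higher from compound 1 to compound 2 (beyond the scatter), is the only comparison at hand, so compound 2 stands highest of the two numbers, with compound 1 the nearest and lower beyond the scatter. Compound 3 `Cc1ccc(NC(=O)Nc2cc(C(C)(C)C)nn2-c2ccccc2)cc1` has not yet been measured in this assay. It differs from compound 2 in one place: 4-methylphenyl in place of 3,4-difluorophenyl on an amide-type nitrogen. Among the compounds with values here, only the step from compound 1 to compound 2 bears on this change, and loosely, since 4-methylphenyl appears in neither measured compound. Because a number 4.4 degrees C higher from compound 1 to compound 2 (beyond the scatter) was large, the new group is expected to land between the two measured numbers rather than beyond compound 2. Compound 3 is therefore estimated at 2.5 degrees C, with a range from 0.5 degrees C to 5 degrees C, an expected step of a number 3.0 degrees C lower from compound 2 to compound 3 (beyond the scatter).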

Compound 3, shift of the target's melting temperature: 4.6 degrees C
The estimate for compound 3 lay 2.1 degrees C below the measured number; the range from low to high includes it.
By their numbers in this assay, from the lowest: compound 1; then compounds 3 and 2 (each within the scatter of the next).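

On the amide-type nitrogen, 4-methylphenyl in place of 3,4-difluorophenyl gives a number 0.90 degrees C lower from compound 2 to compound 3 (within the scatter) in this assay, so these two groups cannot be told apart on this read-out and fluorine on the ring is not needed for a high number in this pair. Methyl in place of ethoxy on an aromatic carbon gives a number 3.5 degrees C higher from compound 1 to compound 3 (beyond the scatter), which shows that a change at that one carbon is enough to separate compound 1 from compound 3, with no fluorine involved in either. Nothing available explains either step.

On these data alone, it remains open whether methoxy, the shorter relative of ethoxy, would read like methyl or like ethoxy at that carbon. Also open, as far as these compounds go, is how a single fluorine, an amine or a carboxylic acid there would read.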